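A chloro on the strongest of three inhibitors

This account rests on a few compounds, and the source may have more. Where it says the series, first, only, none or still open, it means among the compounds named here.

In a functional assay on MCF7 cells (Homo sapiens) for inhibition, read by CCK-8 assay, with a stated time of 72 h (a higher number here means a weaker inhibitor, a lower number a stronger inhibitor), compound 1 `O=C(/C=C/c1cccnc1)NCCCCc1ccc(S(=O)(=O)Nc2ccccc2)cc1` gives 5.03 nM and compound 3 `O=C(/C=C/c1cccnc1)NCCCCCCCc1cccc(S(=O)(=O)Nc2ccccc2)c1` gives 42.6 nM as its reading. Compound 2 `O=C(/C=C/c1cccnc1)NCCCCCCc1cccc(S(=O)(=O)Nc2ccccc2)c1` gives 0.63 nM and that is the lowest number of the three, making it the strongest inhibitor here, with both gaps beyond the scatter. Compound 4 `O=C(/C=C/c1cccnc1)NCCCCCCc1cccc(S(=O)(=O)Nc2ccc(Cl)cc2)c1` is compound 2 with phenyl turned into 4-chlorophenyl. The change chloro in place of hydrogen on an aromatic carbon puts chloro in place of hydrogen on an aromatic carbon, para to a large group. Within the data shown here, no measured pair shows what this change does, so the expected step in this assay is small, towards slightly weaker inhibition and not beyond the scatter. The estimated step of a 1.6-fold higher number from compound 2 to compound 4 (0.20 log units; within the scatter) stays modest. Compound 4 is expected at 1 nM with a likely range of 0.2 nM to 5 nM as its half-maximal inhibitory concentration.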

Compound 4, half-maximal inhibitory concentration: 5.94 nM
Estimate against measurement, compound 4: 5.9-fold (0.77 log units) below, and the stated range ends below it.
By their numbers in this assay, from the lowest: compound 2; then compounds 1 and 4 (each within the scatter of the next); then compound 3.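

The three earlier compounds all carry an unsubstituted phenyl, so they say nothing about this position. Turning phenyl into 4-chlorophenyl gives, in this assay, a 9.4-fold higher number from compound 2 to compound 4 (0.97 log units; beyond the scatter), so a single added chlorine atom here is enough to weaken inhibition. No measurement shown explains why this step occurs.

From the compounds shown here alone, it remains open whether a fluoro, a methoxy or an amine at the same place would cost as much as chloro does. Also open, going by these compounds, is whether the chloro step would be the same on the chains of compound 1 or compound 3.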